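Tert-butyl in place of 4-fluorophenyl beside a carbonyl

The source may report more compounds than this note shows. Statements on the series, on what has been measured and on what is new or still open speak of the compounds shown alone.

Compound 2 `CC(=O)ON(/C=C\C(=O)c1ccc(F)cc1)Cc1ccccc1` carries a 4-fluorophenyl group on a carbonyl carbon. In an assay on RBL-1 cells for inhibition of Polyunsaturated fatty acid 5-lipoxygenase (Rattus norvegicus) (a lower number here means a stronger inhibitor, a higher number a weaker inhibitor), compound 2 gives only a limit of > 25000 nM, not a number. Compound 3 `CC(=O)ON(/C=C\C(=O)c1ccc([N+](=O)[O-])cc1)Cc1ccccc1` likewise reaches only a limit of > 25000 nM in this assay. The step that the two limits leave unreadable from compound 2 to compound 3 therefore cannot be read, since both compounds sit at the limit of > 25000 nM in this assay, at which 2 of the 3 values shown sit. Compound 1 `COC(=O)/C=C\N(O)Cc1ccc(OCc2ccccc2)cc1`, built on a different core, gives 4800 nM in this assay. Compound 4 `CC(=O)ON(/C=C\C(=O)C(C)(C)C)Cc1ccccc1` differs from compound 2 by tert-butyl in place of 4-fluorophenyl on a carbonyl carbon. For the measured compounds named here, no measured step bears on this change, and compound 2 itself offers no number to step from. Compound 4 is therefore expected to stay near the limit, at an estimated 30000 nM with a range of 8000 nM to 100000 nM. The expected step is a step that the limit leaves unreadable from compound 2 to compound 4.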

Compound 4, half-maximal inhibitory concentration: > 25000 nM
Compound 4: only a limit was reported (the forecaster's own chance of this, stated with the estimate: 75%); the middle value is on the limit's open side.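

For the compounds shown here, compound 2 and compound 4 each give only a limit in this assay, not a number, so no step between them can be read. On these data alone, whether tert-butyl or 4-fluorophenyl on a carbonyl carbon gives the stronger inhibitor stays open.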